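The source may hold more compounds than are shown below. What is called first, only, known or untested is meant among the compounds shown, and "the series" means these compounds.

Measured in a functional assay on A549 cells (Homo sapiens) for cytotoxicity, read by sulforhodamine B assay, with a stated time of 48 h; a lower number here means a stronger inhibitor, a higher number a weaker inhibitor:

- compound 1 `COc1ccc(/C=C/C(=O)c2cccc(-c3ccc(F)cc3)c2)cc1`: 11200 nM
- compound 2 `COc1ccc(/C=C/C(=O)c2ccc(N)c(-c3ccc(F)cc3)c2)cc1`: 4310 nM
- compound 3 `COc1ccccc1/C=C/C(=O)c1cccc(-c2cccc(F)c2)c1`: 15500 nM

In this assay, compound 1 at 11200 nM and compound 3 at 15500 nM lie within the scatter of each other. Compound 2 has the lowest number of the three, and the series shows a 2.6-fold lower number from compound 1 to compound 2 (0.41 log units; beyond the scatter). That modest step came with amino in place of hydrogen on an aromatic carbon.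

The next compound, compound 4 `COc1ccc(/C=C/C(=O)c2cccc(Br)c2)cc1`, changes the core of compound 1 elsewhere: bromo in place of 4-fluorophenyl on an aromatic carbon. In words, this is bromo in place of 4-fluorophenyl on an aromatic carbon.

Going by the values given here, no measured compound shows what happens when the 4-fluorophenyl leaves, so the evidence for this change is thin. Among the compounds with values here, the single measured step, a 2.6-fold lower number from compound 1 to compound 2 (0.41 log units; beyond the scatter), bears on it only indirectly, as a guide to how far one change has moved the number in this small set. It gives no direction for the replacement. No step beyond the scatter is therefore expected, though a wide margin is needed on either side. The expected step is a 1.3-fold higher number from compound 1 to compound 4 (0.10 log units; within the scatter). For compound 4 the estimated value is 14000 nM, with an expected range from 5000 nM to 40000 nM.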

Compound 4, half-maximal inhibitory concentration: 34200 nM
For compound 4 the middle estimate is 2.4-fold (0.39 log units) below the measured one, and the stated range covers the measured number.
By their numbers in this assay, from the lowest: compound 2; then compounds 1 and 3 (each within the scatter of the next); then compound 4.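

In this assay, going by these compounds alone, replacing the 4-fluorophenyl on this aromatic carbon, meta to a large group, with bromo gives a 3.1-fold higher number from compound 1 to compound 4 (0.48 log units; beyond the scatter), the first measure of a change at this position. A group of 7 heavy atoms with its six-membered aromatic ring gave way to a single bromine, and the number moved the opposite way from a 2.6-fold lower number from compound 1 to compound 2 (0.41 log units; beyond the scatter), with both steps beyond the scatter, so in this small set the 4-fluorophenyl is the better of the two groups at this position, though the modest step shows that the number does not depend on having that ring there. Nothing measured here accounts for the rise, so the step stands as an observation only.

One step cannot separate the part played by the ring from that of its fluorine, and a plain phenyl, a chloro or a methoxy at the same carbon would each help to place the bromo result on a wider scale. As far as these compounds go, it also remains open whether the amino group that accompanied the lower number in the 4-fluorophenyl series would have the same effect alongside bromo.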